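The source may report more compounds than this note shows. Statements on the series, on what has been measured and on what is new or still open speak of the compounds shown alone.

Compounds measured so far:
compound 1, `OC[C@H]1O[C@@H](n2cnc3c(CSc4c(F)cccc4Cl)ncnc32)[C@H](O)[C@@H]1O`, gives 1510 nM in an assay on isolated protein for binding affinity to Equilibrative nucleoside transporter 1 (Homo sapiens); a higher number here means a weaker inhibitor, a lower number a stronger inhibitor
compound 2, `OC[C@H]1O[C@@H](n2cnc3c(CSc4ccccc4I)ncnc32)[C@H](O)[C@@H]1O`, gives 282 nM in this assay
compound 3, `OC[C@H]1O[C@@H](n2cnc3c(CSc4cccc(I)c4)ncnc32)[C@H](O)[C@@H]1O`, gives 245 nM in this assay

Compound 3 sits at the low end of these three numbers together with compound 2, the two being within the scatter of each other, while compound 1 lies well above both, as the step of a 6.2-fold lower number from compound 1 to compound 3 (0.79 log units; beyond the scatter) shows.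

Compound 4, `O=[N+]([O-])c1cccc(SCc2ncnc3c2ncn3[C@@H]2O[C@H](CO)[C@@H](O)[C@H]2O)c1`, has not yet been measured. Its change from compound 3 is nitro in place of iodo on an aromatic carbon.

Among the measured compounds shown here, none of the measured steps is a close model for this change. The steps of a 5.4-fold lower number from compound 1 to compound 2 (0.73 log units; beyond the scatter) and a 6.2-fold lower number from compound 1 to compound 3 (0.79 log units; beyond the scatter) show that reshaping the halogen pattern on the phenyl ring moves the number modestly, and the step of a 1.2-fold lower number from compound 2 to compound 3 (0.06 log units; within the scatter) shows that shifting the iodine to a different position on the ring leaves the number within the scatter. Swapping iodo for nitro, however, is a change of kind rather than of position, and no measured pair in this set tests it. The expectation is therefore a step of uncertain direction, a 1.6-fold higher number from compound 3 to compound 4 (0.21 log units; within the scatter), centred near no change but with a wide spread either way.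

Compound 4 is thus estimated at 400 nM, with a range from 120 nM to 1300 nM.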

Compound 4, half-maximal inhibitory concentration: 4.79 nM
For compound 4 the middle estimate is 84-fold (1.92 log units) above the measured one; the measured number lies below the stated range.
By their numbers in this assay, from the lowest: compound 4; then compounds 3 and 2 (each within the scatter of the next); then compound 1.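

In this assay, nitro in place of iodo on the aromatic carbon gives a 51-fold lower number from compound 3 to compound 4 (1.71 log units; beyond the scatter) and is a large step, whereas moving the iodine had given only a 1.2-fold lower number from compound 2 to compound 3 (0.06 log units; within the scatter) and stayed within the scatter. So among these compounds, which group sits on the phenyl ring can matter far more than the earlier halogen changes suggested, and the size of the effect stands out again in a 59-fold lower number from compound 2 to compound 4 (1.77 log units; beyond the scatter) and in a 320-fold lower number from compound 1 to compound 4 (2.50 log units; beyond the scatter) as the 3-nitrophenyl group replaces the other two rings. Nothing given here explains what it is about the nitro group that produces a step of this size.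

The compounds shown leave open whether the low number belongs to nitro alone, or whether a nitrile, an amine or a carboxylic acid in the same place on the ring would give a similar one. They also leave open whether nitro would give a similar step at another place on the ring, or alongside a second group such as the chlorine and fluorine of compound 1.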